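Moving a Hydroxyl Along a Two-Carbon Side Chain

This account rests on a few compounds, and the source may have more. Where it says the series, first, only, none or still open, it means among the compounds named here.

Compound 1 `COc1cc2c(c(OC)c1OC)-c1cc3cc(CO)oc3cc1C(O)CC2` and compound 2 `COc1cc2c(c(OC)c1OC)-c1cc3cc(C(C)O)oc3cc1C(O)CC2` share a core and differ only in a side chain. In a functional assay on MIA PaCa-2 cells (Homo sapiens) for cytotoxicity, read by MTT assay, with a stated time of 72 h (on this read-out lower numbers stand for stronger inhibition and higher numbers for weaker inhibition), compound 1 gives 16 nM and compound 2 gives 64 nM, so compound 2 holds the higher, weaker number of the pair. Compound 3 `COc1cc2c(c(OC)c1OC)-c1cc3cc(CCO)oc3cc1C(O)CC2` has the same atoms as compound 2, joined differently: 2-hydroxyethyl in place of 1-hydroxyethyl on an aromatic carbon, with 2-hydroxyethyl in place of 1-hydroxyethyl on an aromatic carbon. Within the data shown here, one measured step bears on this: methyl in place of hydrogen on the chain carbon gave a 4.0-fold higher number from compound 1 to compound 2 (0.60 log units; beyond the scatter), modest but beyond the scatter. In compound 3 the carbon bearing the hydroxyl has no methyl, as in compound 1 at 16 nM. However, no measurement yet covers the longer chain, so only a partial return in this assay is expected. The expected change is a 1.8-fold lower number from compound 2 to compound 3 (0.26 log units; within the scatter). For compound 3 the estimated value is 35 nM, within an expected range of 11 nM to 110 nM.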

Compound 3, half-maximal inhibitory concentration: > 400 nM
Compound 3 gave a limit, no number; the forecaster's own chance of this, stated with the estimate: 2%; at least 11-fold (1.05 log units) between middle value and limit.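

Compound 3 gives only a limit in this assay, not a number: the limit of > 400 nM in this assay, at which 1 of the 3 values shown sits.

The side chains of compound 2 and compound 3 hold the same atoms, yet 2-hydroxyethyl in place of 1-hydroxyethyl gives an at least 6.2-fold higher number from compound 2 to compound 3 (0.79 log units; beyond the scatter), and the comparison with the hydroxymethyl chain gives an at least 25-fold higher number from compound 1 to compound 3 (1.39 log units; beyond the scatter). At this position, on an aromatic carbon next to the ring oxygen, the placement of the hydroxyl along the chain therefore matters, not just which atoms the chain contains, and only compound 1 and compound 2, with the hydroxyl on the chain carbon bound to the aromatic carbon, give measured numbers.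

As far as these compounds go, how far the true value of compound 3 lies from its limit remains open. So does whether a hydroxyl is needed on that chain carbon at all, a question that an amine in its place or a plain ethyl group could address.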